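The compounds below may be only part of what the source reports. "The series", "measured", "known", "first", "only" and "open" are said of these compounds alone.

Measured compounds in an assay on Myocardium (Cavia porcellus) for binding affinity to Voltage-dependent L-type calcium channel subunit alpha-1C (Homo sapiens); a higher number here means weaker binding, a lower number tighter binding:
- compound 1 `CCOC(=O)C1=C(C)NC(SC)=NC1c1cccc([N+](=O)[O-])c1`, compound 1 gives 23 nM
- compound 2 `CCC(C)OC(=O)C1=C(C)NC(SC)=NC1c1cccc([N+](=O)[O-])c1`, compound 2 gives 2.6 nM

Of the two numbers, compound 1 has the higher one; the only step shown, an 8.8-fold lower number from compound 1 to compound 2 (0.95 log units; beyond the scatter), arises from ethyl in place of hydrogen on a saturated chain carbon bound to an oxygen next to a carbonyl group and a saturated chain carbon.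

Compound 3 `CCOC(=O)C1=C(C)NC(N(C)C)=NC1c1cccc([N+](=O)[O-])c1` has not yet been measured. It differs from compound 1 in dimethylamino in place of methylsulfanyl on a carbon with a double bond to nitrogen. For the measured compounds named here, the one measured step changes the ester, not the group on the carbon with a double bond to nitrogen, so it gives no direct guide to this change. With no step of this kind in hand, the outlook rests on the fact that the group leaving and the group entering are of similar size, each with one acceptor and no donor. Compound 3 is therefore expected to stay close to compound 1, with the estimate a 2.2-fold higher number from compound 1 to compound 3 (0.34 log units; beyond the scatter). The estimate for compound 3 in this assay is 50 nM, within 10 nM to 250 nM.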

Compound 3, dissociation constant: 3400 nM
The estimate for compound 3 lay 68-fold (1.83 log units) below the measured number, outside the stated range (above it).
By their numbers in this assay, from the lowest: compound 2; then compound 1; then compound 3.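

In this assay, the group on the carbon with a double bond to nitrogen, between two ring nitrogen atoms, proves far from indifferent: dimethylamino in place of methylsulfanyl brings a 150-fold higher number from compound 1 to compound 3 (2.17 log units; beyond the scatter) and marks this as a position where the choice of group matters greatly. The two groups match in having no ring, no hydrogen-bond donors and one hydrogen-bond acceptor, so those counts alone do not tell how a group will behave at this place. Nothing at hand explains why the number rises so far.

The compounds shown leave open whether a longer sulfur chain such as ethylsulfanyl, or an oxygen group such as methoxy, would stay near compound 1 or move towards compound 3. They also leave open whether the ester of compound 2 would lower the number when paired with dimethylamino.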